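Dithiocarbamate triazole ureas: ethyl versus isopropyl

The source may report more compounds than this note shows. Statements on the series, on what has been measured and on what is new or still open speak of the compounds shown alone.

Measured compounds:
- compound 1 `Cc1ccc(Cn2cc(CSC(=S)N3CCN(C(=O)NC(C)C)CC3)nn2)cc1`: > 128000 nM
- compound 2 `CCNC(=O)N1CCN(C(=S)SCc2cn(Cc3ccc(OC)cc3)nn2)CC1`: > 128000 nM

Compound 2 in a functional assay on SMMC-7721 cells (Homo sapiens) for cytotoxicity, read by MTT assay, with a stated time of 72 h (a lower number here means a stronger inhibitor, a higher number a weaker inhibitor), gives only the assay limit, > 128000 nM, not a number. Compound 1 in this assay likewise reaches only the limit, > 128000 nM. Both values sit at the limit of > 128000 nM in this assay, at which 2 of the 2 values shown sit, so compound 2 stands nowhere distinguishable from compound 1; neither shows measurable activity.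

Compound 3 `COc1ccc(Cn2cc(CSC(=S)N3CCN(C(=O)NC(C)C)CC3)nn2)cc1` differs from compound 2 by methyl in place of hydrogen on a saturated chain carbon bound to an amide-type nitrogen and a saturated chain carbon — methyl in place of hydrogen on a saturated chain carbon bound to an amide-type nitrogen and a saturated chain carbon, which reads ethylcarbamoyl to isopropylcarbamoyl one bond further out. Among the measured compounds shown here, no measured step connects any pair here, so nothing shows this change moving potency in either direction. With compound 1 already carrying the isopropylcarbamoyl group and sitting at the limit of > 128000 nM in this assay, at which 2 of the 2 values shown sit, no shift beyond the scatter is expected; the step that the limit leaves unreadable from compound 2 to compound 3 is estimated as none. Compound 3 is expected to give 200000 nM, most likely again only a limit, within 100000 nM to 600000 nM.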

Compound 3, half-maximal inhibitory concentration: > 128000 nM
Compound 3: a limit, no number; the forecaster's own chance of this, stated with the estimate: 90%; the middle value does not contradict the limit.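

No step linking compound 3 with compound 2 or compound 1 can be read in this assay, as all three values are limits: the limit of > 128000 nM in this assay, at which 3 of the 3 values shown sit.

The compounds shown leave open whether ethylcarbamoyl to isopropylcarbamoyl, or methoxy in place of methyl on an aromatic carbon, changes potency at all.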